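Acetylating the phenol in nitrothiazole amides: cytotoxicity to be measured

The compounds below may be only part of what the source reports. "The series", "measured", "known", "first", "only" and "open" are said of these compounds alone.

Of the compounds shown here, three sharing an amide-linked nitrothiazole have been tested, and a fourth waits for its number. Compound 1 `O=C(Nc1ncc([N+](=O)[O-])s1)c1cc(Cl)ccc1O` carries a free hydroxy group. In an ADME assay on HEK-293T cells (Homo sapiens) for cytotoxicity, read by MTT assay, tested at 25 uM (on this read-out higher numbers stand for a weaker effect at the one concentration tested and lower numbers for a stronger effect), compound 1 gives 100%. Compound 2 `CC(=O)Oc1ccc(Cl)cc1C(=O)Nc1ncc([N+](=O)[O-])s1` differs from compound 1 by acetyl in place of hydrogen on an oxygen on an aromatic ring and in this assay compound 2 gives 59.5%, a change summed up as a number 40.5 percentage points lower from compound 1 to compound 2 (beyond the scatter). Compound 3 `CC(C)c1cc(C(=O)Nc2ncc([N+](=O)[O-])s2)c(O)c(C(C)C)c1` carries two isopropyl groups beside its hydroxy group and is the furthest from compound 1 in this set; the difference between the two cores is not broken down here. In this assay compound 3 gives 29.4%, the lowest of the three numbers.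

Compound 4 `CC(=O)Oc1c(C(=O)Nc2ncc([N+](=O)[O-])s2)cc(C(C)C)cc1C(C)C` stands to compound 3 as compound 2 stands to compound 1, the change being (acetyl in place of hydrogen on an oxygen on an aromatic ring), the same change at the same kind of place. Because a number 40.5 percentage points lower from compound 1 to compound 2 (beyond the scatter), a downward step is expected for the same change here as well. Compound 3 already sits low, and a read-out cannot fall far below zero. The expected step is a number 14.4 percentage points lower from compound 3 to compound 4 (beyond the scatter). For compound 4 the estimate in this assay is therefore 15%, with a plausible range from 0% to 40%.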

Compound 4, a percentage reported as activity, at one concentration (the size of the read-out at that concentration, not a potency): 45.9%
The estimate for compound 4 lay 30.9 percentage points below the measured number, outside the stated range (above it).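

In this assay, on the core of compound 3, acetyl in place of hydrogen on the oxygen gives a number 16.5 percentage points higher from compound 3 to compound 4 (beyond the scatter). Set beside the earlier step, the same change does not carry over from one core to the other, and even its direction reverses: the same change on two cores in this assay, a number 40.5 percentage points lower (beyond the scatter) from compound 1 to compound 2 and a number 16.5 percentage points higher (beyond the scatter) from compound 3 to compound 4, 57 percentage points apart, beyond the scatter of two such steps This shows that in these two pairs the outcome of the change depends on the core that carries it, but it does not show which difference between the cores matters or why the number moves either way, and two pairs make no rule for the series.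

The compounds shown leave open whether a core with a single isopropyl group would follow the pair of compound 1 and compound 2 or the pair of compound 3 and compound 4. They also leave open whether a longer chain such as butanoyl or a ring-bearing group such as benzoyl, in place of acetyl on that oxygen, would behave as acetyl does on each core.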